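The source may hold more compounds than are shown below. What is called first, only, known or untested is meant among the compounds shown, and "the series" means these compounds.

Of the compounds shown here, three built on one shared core have been tested in an ADME assay on the whole organism for cytotoxicity, with Artemia salina as the target, with a stated time of 24 h; a higher number here means that more compound is needed for the effect, a lower number that less compound is needed. Compound 1 `COc1ccc(/C=C/C(=O)c2ccccc2NC(=O)NS(=O)(=O)c2ccc(C)cc2)cc1OC` gives 12.9 ug/mL, compound 2 `Cc1ccc(S(=O)(=O)NC(=O)Nc2ccccc2C(=O)/C=C/c2ccccc2O)cc1` gives 32.3 ug/mL, and compound 3 `Cc1ccc(S(=O)(=O)NC(=O)Nc2ccccc2C(=O)/C=C/c2cc(O)ccc2[N+](=O)[O-])cc1` gives 18.3 ug/mL. The number for compound 3 lies within the scatter of both others, nearest to compound 1 and furthest from compound 2. Compound 4 `C=CCOc1ccc(/C=C/C(=O)c2ccccc2NC(=O)NS(=O)(=O)c2ccc(C)cc2)cc1` differs from compound 3 at the aryl group only: 4-(allyloxy)phenyl in place of 5-hydroxy-2-nitrophenyl on a double-bonded chain carbon bound to a double-bonded chain carbon. Among the earlier changes at this same place, a 2.5-fold higher number from compound 1 to compound 2 (0.40 log units; beyond the scatter) was the sole step beyond the scatter, while a 1.4-fold higher number from compound 1 to compound 3 (0.15 log units; within the scatter) and a 1.8-fold lower number from compound 2 to compound 3 (0.25 log units; within the scatter) stayed within it. Like the 3,4-dimethoxyphenyl of compound 1, the entering group carries no hydrogen-bond donor; the step of a 1.3-fold lower number from compound 3 to compound 4 (0.12 log units; within the scatter) is therefore expected to remain within the scatter. Compound 4 is estimated at 14 ug/mL, between 7 ug/mL and 28 ug/mL.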

Compound 4, concentration for half-maximal effect: 6.11 ug/mL
The estimate for compound 4 lay 2.3-fold (0.36 log units) above the measured number, outside the stated range (below it).
By their numbers in this assay, from the lowest: compound 4; then compounds 1, 3 and 2 (each within the scatter of the next, the first and the last beyond it).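

With the 4-(allyloxy)phenyl group, this position gives a number set apart from all the others in this assay, with a 3.0-fold lower number from compound 3 to compound 4 (0.48 log units; beyond the scatter) and a 5.3-fold lower number from compound 2 to compound 4 (0.72 log units; beyond the scatter) and also a 2.1-fold lower number from compound 1 to compound 4 (0.32 log units; beyond the scatter), each beyond the scatter. Compound 1 also carries no hydrogen-bond donor on this aryl group, so lacking a donor does not by itself set the number here. Nothing available explains these steps.

Going by these compounds, it remains open whether the allyl double bond matters or any ether chain of this size would serve. A propyloxy or a methoxy group on the same phenyl ring would separate the two.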